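Tetrazole regioisomer in the octylphenoxy ketone series

A few compounds are considered here, and "the series" means these few. Any claim that something is new, unique, unknown or untested is made for them only; others in the source may bear on it.

Measured so far:
- compound 1 `CCCCCCCCc1ccc(OCC(=O)Cn2nnc(-c3ccccc3)n2)cc1`: 33%
- compound 2 `CCCCCCCCc1ccc(OCC(=O)Cn2nnc(-c3ccncc3)n2)cc1`: < 5%
- compound 3 `CCCCCCCCc1ccc(OCC(=O)Cn2nnc(C(=O)OC)n2)cc1`: < 5%

In an ADME assay on S9 fraction from liver (Rattus norvegicus) for metabolic stability, read by LC-MS, using NADPH, with a stated time of 30 min (on this read-out lower numbers stand for a less stable compound and higher numbers for a more stable compound), compound 1 gives 33%. For compound 2 the read-out is a limit of the assay, < 5%. For compound 3 the read-out is likewise a limit, < 5%. Two of the three values sit at this limit (the limit of < 5% in this assay, at which 2 of the 3 values shown sit), so compound 3 stands at the lowest point the assay reports, with the step of a number at least 28 percentage points lower from compound 1 to compound 3 (beyond the scatter) and the step of a number at least 28 percentage points lower from compound 1 to compound 2 (beyond the scatter) both beyond the scatter, while the step that the two limits leave unreadable from compound 2 to compound 3 cannot be sized.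

Compound 4 `CCCCCCCCc1ccc(OCC(=O)Cn2nnnc2C(=O)OC)cc1` is to be measured in this assay. Its change from compound 3 is 5-(methoxycarbonyl)-1H-tetrazol-1-yl in place of 5-(methoxycarbonyl)-2H-tetrazol-2-yl on a saturated chain carbon bound to a carbonyl carbon. Among the compounds with values here, none of the measured steps moves the attachment point of the ring in this way; all three exchange the group on an aromatic carbon instead. Within the data shown here, no measured step therefore bears directly on this change, and the only anchor is that compound 3 already sits at the limit. Among the measured compounds shown here, for compound 4 the expected step is a number no lower from compound 3 to compound 4 (the limit leaves the size open), that is, no step readable beyond the scatter. Compound 4 is estimated at 5%, within a range from 0% to 15%, with a fair chance that the assay again returns only the limit.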

Compound 4, percent of the compound remaining: 38%
Estimate against measurement, compound 4: 33 percentage points below; the whole stated range lies below it.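

In this assay, the read-out at this position depends on how the ring is attached as well as on the group it carries: with the same atoms, 5-(methoxycarbonyl)-1H-tetrazol-1-yl in place of 5-(methoxycarbonyl)-2H-tetrazol-2-yl on a saturated chain carbon bound to a carbonyl carbon gives a number at least 33 percentage points higher from compound 3 to compound 4 (beyond the scatter). The earlier steps shown here all exchanged the group on an aromatic carbon and left the attachment of the ring untouched, whereas this step shows that methoxycarbonyl as such does not hold a compound at the bottom of the read-out. For compound 3 the value < 5% is a limit, so the full size of the step stays open at its upper end: the limit of < 5% in this assay, at which 2 of the 4 values shown sit.

On these data alone, whether the 1H-tetrazol-1-yl attachment brings a similar gain with phenyl or pyridin-4-yl in place of methoxycarbonyl remains open, as does the outcome with a carboxylic acid or a primary amide on the ring. The compounds shown also do not tell which part of the structure is lost in this assay, or why the two attachments part so widely.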